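The source may hold more compounds than are shown below. What is called first, only, known or untested is meant among the compounds shown, and "the series" means these compounds.

Of the compounds shown here, two of a shared core have been tested in a functional assay on A549 cells (Homo sapiens) for cytotoxicity, read by MTT assay, with a stated time of 48 h; a lower number here means a stronger inhibitor, a higher number a weaker inhibitor. Compound 1 `CC(C)=CCC/C(C)=C/CC/C(C)=C/CC[C@@H]1[C@@]2(C)CC/C(=N\OCc3cn(-c4c(Cl)cc([N+](=O)[O-])cc4Cl)nn3)C(C)(C)[C@@H]2CC[C@@]1(C)O` gives 11200 nM, while compound 2 `CC(C)=CCC/C(C)=C/CC/C(C)=C/CC[C@@H]1[C@@]2(C)C/C(=C\c3ccc(OCc4cn(-c5ccc(F)cc5)nn4)cc3)C(=O)C(C)(C)[C@@H]2CC[C@@]1(C)O` gives 55200 nM, the higher of the two numbers; the gap between them lies beyond the usual scatter. Compound 3 `CC(C)=CCC/C(C)=C/CC/C(C)=C/CC[C@@H]1[C@@]2(C)C/C(=C\c3ccc(OCc4cn(-c5ccncc5)nn4)cc3)C(=O)C(C)(C)[C@@H]2CC[C@@]1(C)O` differs from compound 2 only in pyridin-4-yl in place of 4-fluorophenyl on an aromatic nitrogen. Nothing measured here tells how such a swap on this ring moves the readout. A modest shift toward a lower number, or none beyond the scatter, is expected from compound 2 to compound 3, namely a 1.4-fold lower number from compound 2 to compound 3 (0.14 log units; within the scatter). Compound 3 is therefore estimated at 40000 nM, within 15000 nM to 100000 nM.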

Compound 3, half-maximal inhibitory concentration: 34000 nM
Compound 3: middle estimate off by 1.2-fold (0.07 log units), on the high side; the measured number falls inside the stated range.
By their numbers in this assay, from the lowest: compound 1; then compounds 3 and 2 (each within the scatter of the next).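

In this assay, among the compounds shown here, the swap of 4-fluorophenyl for pyridin-4-yl on an aromatic nitrogen gives a 1.6-fold lower number from compound 2 to compound 3 (0.21 log units; within the scatter) and so offers the first direct reading at this position. Putting a ring nitrogen with one hydrogen-bond acceptor in place of the fluorine-bearing carbon ring leaves no change that can be told from the scatter. Nothing here offers a measured explanation for this result. As far as these compounds go, whether a methyl group or a benzyl group at this position would move the number remains open. So does the effect of a carboxylic acid or an amine on the pyridine ring.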